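Hydroxy to methoxy: the step to compound 4

The source may report more compounds than this note shows. Statements on the series, on what has been measured and on what is new or still open speak of the compounds shown alone.

Three close relatives share one core and differ in the aromatic ring at the far end. In a functional assay on A549 cells (Homo sapiens) for antiproliferative activity, read by MTT assay, with a stated time of 72 h (a lower number here means a stronger inhibitor, a higher number a weaker inhibitor), compound 1 `O=C(N/N=C/c1cccc(Cl)c1Cl)Nc1ccc(Oc2ccnc3[nH]ccc23)c(F)c1` is recorded as "not active" (no number reported), with no number attached. Compound 2 `O=C(N/N=C/c1ccc(Cl)c(Cl)c1)Nc1ccc(Oc2ccnc3[nH]ccc23)c(F)c1` gives 2650 nM, and compound 3 `O=C(N/N=C/c1ccc(O)cc1)Nc1ccc(Oc2ccnc3[nH]ccc23)c(F)c1` gives 3760 nM. Compound 3 thus has one numerical neighbour, and the two values cannot be ranked: a 1.4-fold higher number from compound 2 to compound 3 (0.15 log units; within the scatter) is a step within the scatter of repeated measurements.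

Compound 4 `COc1ccc(/C=N/NC(=O)Nc2ccc(Oc3ccnc4[nH]ccc34)c(F)c2)cc1` makes one small edit to compound 3: methyl in place of hydrogen on an oxygen on an aromatic ring. This is methyl in place of hydrogen on an oxygen on an aromatic ring, so 4-hydroxyphenyl becomes 4-methoxyphenyl. Among the measured compounds shown here, no measured step shows this exact change. The nearest evidence is the replacement of 3,4-dichlorophenyl by 4-hydroxyphenyl, where a 1.4-fold higher number from compound 2 to compound 3 (0.15 log units; within the scatter) stayed within the scatter despite being a larger edit. Compound 1 is the caution, since a change on this ring can also leave no measurable number. The expected result in this assay is therefore no shift beyond the scatter, with the estimate being a 1.1-fold lower number from compound 3 to compound 4 (0.03 log units; within the scatter). Compound 4 is expected at about 3500 nM, within an estimated range of 1500 nM to 8500 nM.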

Compound 4, half-maximal inhibitory concentration: 3980 nM
Beside the measured number, compound 4's estimate is 1.1-fold (0.06 log units) below it, and the stated range covers the measured number.
By their numbers in this assay, from the lowest: compounds 2, 3 and 4 (each within the scatter of the next).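

In this assay, putting a methyl on the oxygen of compound 3 gives a 1.1-fold higher number from compound 3 to compound 4 (0.02 log units; within the scatter), so at this oxygen on an aromatic ring, hydroxy and methoxy cannot be told apart. The wider swap gives a 1.5-fold higher number from compound 2 to compound 4 (0.18 log units; within the scatter), which also stays within the scatter, so the three compounds with numbers now form a group that cannot be ranked, while compound 1, recorded as "not active" (no number reported), goes against this picture of a ring that accepts every edit. No measurement at hand explains why the hydroxy and methoxy compounds read alike.

Going by these compounds, it remains open whether a longer chain on this oxygen, such as ethyl or propyl, would read the same, or whether an amine or a carboxylic acid in place of the hydroxy group would hold the number in this range. Among the compounds shown here, every step between two numbers so far lies within the scatter, so whether any group at this position can move the number beyond it, in either direction, stays unanswered.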